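Oxazoline to thiazoline swap on an inactive sulfonyl core

The compounds below may be only part of what the source reports. "The series", "measured", "known", "first", "only" and "open" are said of these compounds alone.

Compound 1 `O=S(=O)(CC1=NCCO1)c1n[nH]cc1-c1ccc(Cl)cc1` is assessed in a functional assay, tested at 75 ug/mL (a higher number here means a stronger effect of the compound at the concentration tested, a lower number a weaker effect), where compound 1 gives "not active" (no number reported), so no single number stands for it; the same holds for compound 3 `O=S(=O)(CC1=NCCO1)C1=NNCC1c1ccccc1`, which in this assay also gives "not active" (no number reported). Among the measured compounds shown here, the one numbered reading belongs to compound 2 `O=S(=O)(CC1=NCCO1)c1n[nH]cc1-c1ccccc1`, which in this assay gives 55.6%. For the measured compounds named here, no step between two numbered compounds exists, so nothing shows how large a change of this kind usually is.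

Compound 4 `O=S(=O)(CC1=NCCS1)c1n[nH]cc1-c1ccc(Cl)cc1` carries the change (a group of 5 heavy atoms (3 carbon, 1 nitrogen, 1 sulfur; one five-membered non-aromatic ring with 2 hetero atoms) in place of a group of 5 heavy atoms (3 carbon, 1 nitrogen, 1 oxygen; one five-membered non-aromatic ring with 2 hetero atoms), on a saturated chain carbon bound to a sulfonyl sulfur). The group that leaves and the group that enters match each other in every count but the one hetero atom; only compound 1 gives a reference point, and that is an entry without a number. The expectation is that compound 4 stays close to compound 1 and most likely returns no number either; if a number is reported, compound 4 is estimated at 12%, within 0% to 40%.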

Compound 4, a percentage reported as activity, at one concentration (the size of the read-out at that concentration, not a potency): "not active" (no number reported)
No number was reported for compound 4, and the estimate cannot be compared.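

In this assay compound 4 gives "not active" (no number reported), and compound 1 gives "not active" (no number reported), so no step can be read between them. No measured evidence bears on this result. The compounds shown leave open what the sulfur-containing ring does on a core with a numbered reading, such as compound 2 at 55.6%.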